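A few compounds are considered here, and "the series" means these few. Any claim that something is new, unique, unknown or untested is made for them only; others in the source may bear on it.

Measured compounds:
- compound 1, `CCOC(=O)C1=Cc2ccccc2OC1(OCc1cn(-c2cccc(OC)c2)nn1)C(F)(F)F`: > 150000 nM
- compound 2, `CCOC(=O)C1=Cc2ccccc2OC1(OCc1cn(-c2ccc([N+](=O)[O-])cc2)nn1)C(F)(F)F`: > 150000 nM

In a functional assay on HeLa cells (Homo sapiens) for inhibition, read by MTT assay, with a stated time of 24 h (on this read-out lower numbers stand for stronger inhibition and higher numbers for weaker inhibition), compound 1 gives > 150000 nM, which is a limit of the assay and not a number. In this assay compound 2 likewise gives > 150000 nM, again a limit rather than a number. Within the data shown here, the one step between measured compounds, a step that the two limits leave unreadable from compound 1 to compound 2, therefore cannot be read in size or direction. Compound 2 thus stands at the limit of > 150000 nM in this assay, at which 2 of the 2 values shown sit, with no value beyond a limit to anchor it.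

Compound 3, `CCOC(=O)C1=Cc2ccccc2OC1(OCc1cn(-c2ccc(C)cc2)nn1)C(F)(F)F`, differs from compound 2 by methyl in place of nitro on an aromatic carbon. Among the measured compounds shown here, no measured step bears on this change: the only step available is unreadable, so nothing shows how the group on the aromatic carbon affects the read-out in this assay. The expectation is therefore that compound 3 stays where compound 2 stands, a step from compound 2 to compound 3 of a step that the limit leaves unreadable from compound 2 to compound 3, which is to say none beyond the scatter. Compound 3 is accordingly estimated at 200000 nM, with a range from 100000 nM to 400000 nM, and most likely the assay reports only a limit for it.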

Compound 3, half-maximal inhibitory concentration: 25100 nM
Estimate against measurement, compound 3: 8.0-fold (0.90 log units) above, outside the stated range (below it).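

In this assay, among these compounds, methyl in place of nitro on an aromatic carbon, para to a large group, gives an at least 5.9-fold lower number from compound 2 to compound 3 (0.77 log units; beyond the scatter), the first sign that the group at this place can move the read-out at all. 4-Methylphenyl in place of 3-methoxyphenyl on the aromatic nitrogen gives an at least 5.9-fold lower number from compound 1 to compound 3 (0.77 log units; beyond the scatter), so the change from either of the other two compounds leads to a lower number, and compound 3 is the only one of the three with a value that is a number rather than a limit. The step between the other two compounds still cannot be read, and both steps from them to compound 3 are known only as minimum sizes, with the two compounds remaining at a limit of the assay: the limit of > 150000 nM in this assay, at which 2 of the 3 values shown sit.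

Going by these compounds, whether an amine, a carboxylic acid or a longer chain such as ethyl on this aromatic carbon would lower the number as methyl does remains open. Also open, on these data alone, are the full size of both steps and whether the methyl group would have the same effect at another place on the six-membered aromatic ring.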